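The source may report more compounds than this note shows. Statements on the series, on what has been measured and on what is new or still open speak of the compounds shown alone.

Measured compounds in a physicochemical assay for solubility, with a stated time of 3 days, at pH 2; a higher number here means a more soluble compound, a lower number a less soluble compound:
compound 1, `CN1CCC(Oc2ccc(-c3nc4cc(C(N)=O)ccc4[nH]3)cc2)C1`: "not determined" (no result reported)
compound 2, `NC(=O)c1ccc2[nH]c(-c3ccc(OCC4CCNCC4)cc3)nc2c1`: > 400000 nM
compound 3, `COc1ccc(CN2CCC(COc3ccc(-c4nc5cc(C(N)=O)ccc5[nH]4)cc3)CC2)cc1`: "not determined" (no result reported)

Compound 2 returns only a limit in this assay, > 400000 nM, not a number. For compound 1 and compound 3 this assay reports no result, so compound 2 stands as the only entry with any figure at all, and that figure is a limit; the entry the limit of > 400000 nM in this assay, at which 1 of the 3 values shown sits, records that one of the three values sits at it. Compound 4, `CC(=O)N1CCCCC1CCOc1ccc(-c2nc3cc(C(N)=O)ccc3[nH]2)cc1`, is not yet measured. Relative to compound 2 it carries (1-acetylpiperidin-2-yl)methyl in place of piperidin-4-yl on a saturated chain carbon bound to an oxygen on an aromatic ring. For the measured compounds named here, no step between measured compounds exists in this assay, so the size of the change can only be anticipated. The step from compound 2 to compound 4 is expected to be an at least 4.0-fold lower number from compound 2 to compound 4 (0.60 log units; beyond the scatter), downward and beyond the usual scatter. Compound 4 is estimated at 100000 nM, within a range of 20000 nM to 400000 nM.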

Compound 4, solubility: > 400000 nM
Compound 4: a limit, no number; the forecaster's own chance of this, stated with the estimate: 25%; at least 4.0-fold (0.60 log units) between middle value and limit.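

In this assay, for the compounds shown here, compound 2 and compound 4 both return limits, not numbers, and no step between them can be read. On these data alone, whether (1-acetylpiperidin-2-yl)methyl in place of piperidin-4-yl shifts the read-out at all stays open.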